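Methylsulfanyl in place of methoxy: expectation for compound 4

The source may hold more compounds than are shown below. What is called first, only, known or untested is meant among the compounds shown, and "the series" means these compounds.

In a functional assay on cells (Homo sapiens), read by thymidine incorporation (a higher number here means a weaker inhibitor, a lower number a stronger inhibitor), compound 1 `Cc1cc(NCc2cccnc2)n2ncc(Br)c2n1` gives 1800 nM. Alongside it, compound 2 `Brc1cnn2c(NCc3cccnc3)cc(C3CC3)nc12` gives 1500 nM. The reference point here, compound 3 `COc1cc(NCc2cccnc2)n2ncc(Br)c2n1`, gives 2000 nM, which places it within the scatter of both others, so the three values do not separate.

The unmeasured compound 4 `CSc1cc(NCc2cccnc2)n2ncc(Br)c2n1` has methylsulfanyl in place of methoxy on an aromatic carbon, next to the ring nitrogen (methylsulfanyl in place of methoxy on an aromatic carbon). The rest of the structure is unchanged.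

Among the compounds with values here, three measured steps bear on this change, since all of them exchange groups on that same aromatic carbon. The first is a 1.2-fold lower number from compound 1 to compound 2 (0.08 log units; within the scatter), the second is a 1.1-fold higher number from compound 1 to compound 3 (0.05 log units; within the scatter), and the third is a 1.3-fold higher number from compound 2 to compound 3 (0.12 log units; within the scatter). All three lie within the scatter. Within the data shown here, no measured compound carries methylsulfanyl, so the evidence is indirect and covers only methyl, cyclopropyl and methoxy at this place.

On that basis, no step beyond the scatter is expected in this assay, and no direction can be favoured. The estimated change is a 1.1-fold lower number from compound 3 to compound 4 (0.05 log units; within the scatter), which is expected to remain within the scatter. For compound 4 the expected value is 1800 nM, with an estimated range of 900 nM to 3600 nM.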

Compound 4, half-maximal inhibitory concentration: 990 nM
Beside the measured number, compound 4's estimate is 1.8-fold (0.26 log units) above it; low and high end bracket the measured number.
By their numbers in this assay, from the lowest: compounds 4, 2, 1 and 3 (each within the scatter of the next, the first and the last beyond it).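

In this assay, within the data shown here, the exchange of methoxy for methylsulfanyl on this aromatic carbon gives a 2.0-fold lower number from compound 3 to compound 4 (0.31 log units; beyond the scatter) as the first step at this position that lies beyond the scatter, and a modest one, whereas the exchanges among methyl, cyclopropyl and methoxy all stayed within it. Against the other two groups, methylsulfanyl does not separate: a 1.5-fold lower number from compound 2 to compound 4 (0.18 log units; within the scatter) and a 1.8-fold lower number from compound 1 to compound 4 (0.26 log units; within the scatter) both remain within the scatter, so the position shows a difference only between methylsulfanyl and methoxy, not a general gain for methylsulfanyl over every group tried here. Nothing measured on these compounds accounts for this difference between two groups that match in heavy-atom count and in hydrogen-bond donors and acceptors.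

Going by these compounds, it remains open whether the lower number persists with a longer chain on the sulfur, such as ethylsulfanyl, or with a sulfur-free group of another kind at this carbon, such as dimethylamino or a carboxylic acid. On these data alone, it is also open whether methylsulfanyl gives a step of the same size when the rest of the structure changes, since the bromo group and the remainder of the shared core stay fixed throughout these compounds.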